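The compounds below may be only part of what the source reports. "The series", "measured", "known", "first", "only" and "open" are said of these compounds alone.

Measured compounds:
compound 1, `O=C(CSc1nnc(-c2ccncc2)o1)N/N=C/c1ccc(Cl)cc1`, 15700 nM in a functional assay on HepG2 cells (Homo sapiens) for cytotoxicity, read by MTT assay, with a stated time of 48 h; on this read-out higher numbers stand for weaker inhibition and lower numbers for stronger inhibition
compound 2, `O=C(CSc1nnc(-c2ccncc2)o1)N/N=C/c1ccc(Br)cc1`, 18600 nM in this assay

Compound 2 holds the highest of the two numbers, with compound 1 nearest at a 1.2-fold higher number from compound 1 to compound 2 (0.07 log units; within the scatter), a gap within the scatter. Compound 3, `O=C(CSc1nnc(-c2ccncc2)o1)N/N=C/c1ccc(O)cc1`, differs from compound 2 by hydroxy in place of bromo on an aromatic carbon, that is, 4-bromophenyl to 4-hydroxyphenyl. For the measured compounds named here, the only measured step, from chloro to bromo, was small, and nothing measured bears on a hydroxy group, so no step beyond the scatter is expected. Compound 3 is therefore estimated at 20000 nM, between 7000 nM and 60000 nM, a step of a 1.1-fold higher number from compound 2 to compound 3 (0.03 log units; within the scatter).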

Compound 3, half-maximal inhibitory concentration: 5510 nM
Compound 3: the middle estimate sits 3.6-fold (0.56 log units) above what was measured; measured number below the stated range.
By their numbers in this assay, from the lowest: compound 3; then compounds 1 and 2 (each within the scatter of the next).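

In this assay, this position proves sensitive to the group it carries, which the exchange of one halogen for the other had not shown: hydroxy in place of bromo gives (a 3.4-fold lower number from compound 2 to compound 3 (0.53 log units; beyond the scatter)), and hydroxy in place of chloro gives (a 2.8-fold lower number from compound 1 to compound 3 (0.45 log units; beyond the scatter)). Both steps lie beyond the scatter and point the same way, towards stronger inhibition. Nothing available explains this shift.

As far as these compounds go, whether an amine or a carboxylic acid at this position would match hydroxy remains open. So does whether a methoxy group would keep the lower number.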